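The source may hold more compounds than are shown below. What is called first, only, known or untested is meant among the compounds shown, and "the series" means these compounds.

In a functional assay on HepG2 cells (Homo sapiens) for inhibition, read by MTT assay, with a stated time of 72 h (a higher number here means a weaker inhibitor, a lower number a stronger inhibitor), three compounds have been measured:
compound 1 `Cc1cccc(-n2cc(COc3cccc(NC(=O)Nc4ccc(Cl)c(C(F)(F)F)c4)c3)nn2)c1` gives 7270 nM;
compound 2 `CCc1ccc(-n2cc(COc3cccc(NC(=O)Nc4ccc(Cl)c(C(F)(F)F)c4)c3)nn2)cc1` gives 1950 nM;
compound 3 `O=C(Nc1cccc(OCc2cn(-c3ccccc3F)nn2)c1)Nc1ccc(Cl)c(C(F)(F)F)c1` gives 1520 nM.

Compound 2 stands second highest of the three: compound 3 lies within the scatter of it (a 1.3-fold lower number from compound 2 to compound 3 (0.11 log units; within the scatter)), while compound 1 sits clearly apart (a 3.7-fold lower number from compound 1 to compound 2 (0.57 log units; beyond the scatter)). Compound 4 `O=C(Nc1cccc(OCc2cn(-c3cccc(C(F)(F)F)c3)nn2)c1)Nc1ccc(Cl)c(C(F)(F)F)c1` is not yet measured and differs from compound 2 in one place: 3-(trifluoromethyl)phenyl in place of 4-ethylphenyl on an aromatic nitrogen. All three known steps swap the group on this same aromatic nitrogen: a 3.7-fold lower number from compound 1 to compound 2 (0.57 log units; beyond the scatter), a 4.8-fold lower number from compound 1 to compound 3 (0.68 log units; beyond the scatter) and a 1.3-fold lower number from compound 2 to compound 3 (0.11 log units; within the scatter). Two swaps moved the number modestly, one not at all, so a modest step in this assay is plausible, and a higher number seems the likelier side because compound 1, the other 3-substituted phenyl, gives 7270 nM. Compound 4 is therefore expected near 3200 nM, between 1200 nM and 8500 nM, an expected step of a 1.6-fold higher number from compound 2 to compound 4 (0.22 log units; within the scatter).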

Compound 4, half-maximal inhibitory concentration: 1270 nM
Compound 4: the middle estimate sits 2.5-fold (0.40 log units) above what was measured; low and high end bracket the measured number.
By their numbers in this assay, from the lowest: compounds 4, 3 and 2 (each within the scatter of the next); then compound 1.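

In this assay, trifluoromethyl in place of methyl on the same phenyl ring separates the two compounds clearly (a 5.7-fold lower number from compound 1 to compound 4 (0.76 log units; beyond the scatter)), so the 3-position substituent matters, and a substituent at that position need not give a high number. The other two comparisons stay within the scatter (a 1.5-fold lower number from compound 2 to compound 4 (0.19 log units; within the scatter); a 1.2-fold lower number from compound 3 to compound 4 (0.08 log units; within the scatter)), leaving compound 1 alone apart from the other three. Every group shown on this aromatic nitrogen is a substituted phenyl, so the effect of an amine or a carboxylic acid on that phenyl remains open. Nothing measured here gives a reason for these steps.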